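Carboxyphenyl ether: moving the carboxylate from compound 3 to compound 4

The source may hold more compounds than are shown below. What is called first, only, known or untested is meant among the compounds shown, and "the series" means these compounds.

Measured compounds:
compound 1, `COC(=O)c1ccc(OCCCCOc2ccc(C(=O)CC3CCCC3)c(C)c2C)cc1`, 24.2%
compound 2, `CCCC(=O)c1ccc(OCCCCOc2cc(C(=O)O)ccc2OC)c(C)c1O`, 64.2%
compound 3, `Cc1c(OCCCCOc2cccc(C(=O)O)c2)ccc(C(=O)CC(C)C)c1C`, 18.3%

In an assay on HEK293 cells for positive allosteric modulation of metabotropic glutamate receptor 3 (Rattus norvegicus), read by thallium flux, with a stated time of 2.5 min (on this read-out lower numbers stand for smaller maximal responses and higher numbers for larger maximal responses), compound 3 gives the lowest of the three numbers. Compound 1 gives 24.2%, which stands within the scatter of compound 3, so no order between these two is claimed. Compound 2 gives 64.2%, well beyond the scatter above compound 3; compound 2 also carries a different pattern on both aryl ends, so its gap to compound 3 cannot be assigned to one change.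

Compound 4, `Cc1c(OCCCCOc2ccccc2C(=O)O)ccc(C(=O)CC(C)C)c1C`, is not yet measured. It differs from compound 3 only in the position of the carboxylate on the aryl ether: 2-carboxyphenyl in place of 3-carboxyphenyl on an oxygen on a saturated carbon

Among the measured compounds shown here, no measured pair isolates this change, so the step from compound 3 to compound 4 in this assay cannot be read from the data. The expected step is small, in either direction, and most likely none beyond the scatter: the estimate for compound 4 is 22%, within 8% to 45%, which means an expected step of a number 3.7 percentage points higher from compound 3 to compound 4 (within the scatter).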

Compound 4, largest response reached (reported as percent of maximum), in percent of the reference or control that the assay uses: 30.7%
Compound 4: middle estimate off by 8.7 percentage points, on the low side; measured number inside the range.
By their numbers in this assay, from the lowest: compounds 3, 1 and 4 (each within the scatter of the next, the first and the last beyond it); then compound 2.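

In this assay, among the compounds shown here, 2-carboxyphenyl in place of 3-carboxyphenyl on an oxygen on a saturated carbon gives a number 12.4 percentage points higher from compound 3 to compound 4 (beyond the scatter), the first step that rests on a single change. The two compounds hold the same atoms, joined differently, so the step concerns the place of the carboxylate on the aryl ether and not a change of group. No measurement at hand accounts for this step.

Going by these compounds, whether a tetrazole or an amide in place of the carboxylic acid of compound 4 would keep, widen or lose this step remains open. The steps to compound 1 and compound 2 cannot be read, as each differs from compound 3 and compound 4 in more than one place.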